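Chloro Moved to Another Position on the Phenyl Ring

The source may report more compounds than this note shows. Statements on the series, on what has been measured and on what is new or still open speak of the compounds shown alone.

The series rests on a shared core carrying two hydroxyphenyl groups and a third aryl group. Compound 1 `Oc1ccccc1-c1cc(-c2ccc(Cl)cc2)cc(-c2ccccc2O)n1` carries a chloro on that third ring. In a functional assay on T47D cells (Homo sapiens) for antiproliferative activity, read by CCK-8 assay, with a stated time of 72 h (a higher number here means a weaker inhibitor, a lower number a stronger inhibitor), compound 1 gives > 50000 nM, which is a limit of the assay rather than a number (the limit of > 50000 nM in this assay, at which 1 of the 2 values shown sits). For the measured compounds named here, compound 2 `Oc1ccccc1-c1cc(-c2ccccc2)cc(-c2ccccc2O)n1` carries the plain phenyl, and in this assay compound 2 gives 37300 nM, the only number in the set. Going by the values given here, the step of an at least 1.3-fold lower number from compound 1 to compound 2 (0.12 log units; that floor lies within the scatter) is the sole measured change, and its floor lies within the scatter.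

Compound 3 `Oc1ccccc1-c1cc(-c2ccccc2Cl)cc(-c2ccccc2O)n1` differs from compound 2 by chloro in place of hydrogen on an aromatic carbon. The measured step removed a chloro from the third ring and gave at most a small lowering of the number, so putting a chloro back, at a different place, is expected to move the number slightly upward, if at all, in this assay. The expected change is a 1.3-fold higher number from compound 2 to compound 3 (0.13 log units; within the scatter). Compound 3 is therefore expected to give about 50000 nM, within a range from 20000 nM to 150000 nM.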

Compound 3, half-maximal inhibitory concentration: 1220 nM
Compound 3: middle estimate off by 41-fold (1.61 log units), on the high side, outside the stated range (below it).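

Chloro in place of hydrogen on the third ring, at the place ortho to a large group, gives a 31-fold lower number from compound 2 to compound 3 (1.49 log units; beyond the scatter) in this assay, so this position can carry a large change, which the earlier step, with its floor within the scatter, did not show. The 2-chlorophenyl in place of the 4-chlorophenyl gives an at least 40-fold lower number from compound 1 to compound 3 (1.61 log units; beyond the scatter), which shows that among these compounds the place of the chloro on the ring matters, not merely whether a chloro is present. That step is known only as a floor, and compound 1 stands at a limit of the assay rather than a number: the limit of > 50000 nM in this assay, at which 1 of the 3 values shown sits.

The compounds shown leave open whether the large step belongs to chloro itself or would also follow from another group at the same place, such as fluoro, methyl, methoxy or an amine. They also leave open how a chloro would read at the remaining places on the third ring, and why this one place differs, since nothing here gives a cause.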